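Swapping the aryl ether on the acetal side chain

The source may report more compounds than this note shows. Statements on the series, on what has been measured and on what is new or still open speak of the compounds shown alone.

Three compounds share a core built around a cyclic acetal carrying a pentenoic acid chain and a pyridin-3-yl group. Compound 1 `N#Cc1ccccc1C1OCC(C/C=C\CCC(=O)O)C(c2cccnc2)O1` gives 245 nM in a functional assay for inhibition, with Homo sapiens as the target; on this read-out lower numbers stand for tighter binding and higher numbers for weaker binding. Going by the values given here, compound 2 `O=C(O)CC/C=C\CC1COC(c2cccnc2)OC1c1cccnc1` gives 759 nM; the step of a 3.1-fold higher number from compound 1 to compound 2 (0.49 log units; beyond the scatter) is the only single-point change measured here. Compound 3 `COc1ccc(OC(C)(C)C2OCC(C/C=C\CCC(=O)O)C(c3cccnc3)O2)cc1` gives 302 nM, the second highest of the three numbers; its value and that of compound 1 lie within the usual scatter of each other, while compound 2 sits beyond the scatter above it.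

Compound 4 `CC(C)(Oc1ccccc1[N+](=O)[O-])C1OCC(C/C=C\CCC(=O)O)C(c2cccnc2)O1` differs from compound 3 in one place: 2-nitrophenyl in place of 4-methoxyphenyl on an oxygen on a saturated carbon. Among the compounds with values here, no measured step touches this aryl ether, since the one step known changes a different site, so nothing here shows how this swap should move the number. The step of a 1.1-fold higher number from compound 3 to compound 4 (0.03 log units; within the scatter) is therefore expected to stay within the scatter, in either direction. Compound 4 is estimated at 320 nM, with a likely range from 100 nM to 1000 nM.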

Compound 4, dissociation constant: 11.2 nM
Beside the measured number, compound 4's estimate is 29-fold (1.46 log units) above it, outside the stated range (below it).
By their numbers in this assay, from the lowest: compound 4; then compounds 1 and 3 (each within the scatter of the next); then compound 2.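

In this assay, putting 2-nitrophenyl in place of 4-methoxyphenyl on this oxygen gives a 27-fold lower number from compound 3 to compound 4 (1.43 log units; beyond the scatter), which marks a much tighter binder on this read-out. The only other single-place change shown, a 3.1-fold higher number from compound 1 to compound 2 (0.49 log units; beyond the scatter), sits at a different site and is modest, so this aryl ether is now the most sensitive place seen in the series, and the group on this oxygen clearly matters for the number. Nothing measured here bears on why the number falls so far.

On these data alone, the swap changes both the substituent and its place on the ring, so it remains open whether the nitro group itself or its 2-position carries the drop. A 4-nitrophenyl or a 2-methoxyphenyl group on this oxygen would separate the two, and a plain phenyl would give a reference point.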